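This account rests on a few compounds, and the source may have more. Where it says the series, first, only, none or still open, it means among the compounds named here.

Compound 1 `Oc1ccc(Nc2cncc(N3CC4CC(C3)N4)c2)cc1` and compound 2 `Clc1cccc(Nc2ccc(N3CC4CC(C3)N4)nn2)c1` have been measured in an assay on cell membranes for displacement of a labelled ligand from Neuronal acetylcholine receptor; alpha4/beta2 (Rattus norvegicus); a higher number here means a weaker inhibitor, a lower number a stronger inhibitor. In this assay compound 1 gives 0.342 nM. Within the data shown here, compound 2 in this assay gives 1540 nM, the higher of the two numbers measured so far; compound 1 shows the lower one, and the gap between the two values lies far beyond the scatter of repeated measurements. Among the measured compounds shown here, compound 2 and compound 1 differ in more than one place, both in the shared core and in the group on the nitrogen, so no single step between them can be drawn from the two values.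

Compound 3 `Clc1ccc(Nc2ccc(N3CC4CC(C3)N4)nn2)cc1` has not yet been measured in this assay. It differs from compound 2 in one place (4-chlorophenyl in place of 3-chlorophenyl on a nitrogen on an aromatic ring). For the measured compounds named here, no measured pair shows this change, so the size of the step cannot be read from the data. The expected step of a 1.5-fold lower number from compound 2 to compound 3 (0.19 log units; within the scatter) is small, within the scatter or barely beyond it, in no firm direction. Compound 3 is therefore estimated to give 1000 nM in this assay, within a range from 250 nM to 4000 nM.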

Compound 3, inhibition constant: 90.4 nM
Estimate against measurement, compound 3: 11-fold (1.04 log units) above; the whole stated range lies above it.
By their numbers in this assay, from the lowest: compound 1; then compound 3; then compound 2.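

In this assay the change from 3-chlorophenyl to 4-chlorophenyl on a nitrogen on an aromatic ring gives a 17-fold lower number from compound 2 to compound 3 (1.23 log units; beyond the scatter) and counts as a large step. The two groups carry the same atoms and the same counts, so this pair shows that the number at this position responds to where the chlorine stands on the phenyl ring and not only to which atoms are present, something the first two compounds, which differ in more than one place, could not show. No measurement is at hand that would explain why the placement of the chlorine matters this much.

Whether the chlorine itself is needed stays open, since only these two placements are shown and neither a fluorine, a methoxy group, a nitrile nor a plain phenyl ring appears in its stead. Steps from compound 1 to the other two compounds cannot be read, so it also stays open whether 4-chlorophenyl would give a lower number than 3-chlorophenyl on the core of compound 1.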